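Phenyl for pyridin-2-yl next to the ring nitrogen

The compounds below may be only part of what the source reports. "The series", "measured", "known", "first", "only" and "open" are said of these compounds alone.

Going by the values given here, compound 2 `Oc1cccc(-c2cc(-c3ccc(Cl)cc3)nc(-c3ccccn3)c2)c1` gives 8090 nM in a functional assay on DU-145 cells (Homo sapiens) for cytotoxicity, read by CCK-8 assay and cell counting, with a stated time of 2 days (on this read-out lower numbers stand for stronger inhibition and higher numbers for weaker inhibition), the lowest of the two numbers so far. Among the compounds with values here, compound 1 `Oc1cccc(-c2cc(-c3ccc(Cl)cc3)nc(-c3cccnc3)c2)c1` gives 26800 nM; the step of a 3.3-fold lower number from compound 1 to compound 2 (0.52 log units; beyond the scatter) is the only measured step on the series, and it is the only one that bears on the change considered here. Compound 3 `Oc1cccc(-c2cc(-c3ccccc3)nc(-c3ccc(Cl)cc3)c2)c1` differs from compound 2 in one place: phenyl in place of pyridin-2-yl on an aromatic carbon. The measured step moved the ring nitrogen; the new step removes it. Within the data shown here, nothing measured shows what the absence of that nitrogen does, and the one step at this position was modest, so a modest step is expected, more likely upward than downward, because a 3.3-fold lower number from compound 1 to compound 2 (0.52 log units; beyond the scatter) came with the pyridin-2-yl nitrogen that compound 3 lacks. The expected step is a 1.9-fold higher number from compound 2 to compound 3 (0.27 log units; within the scatter). Compound 3 is estimated at 15000 nM in this assay, within 5000 nM to 50000 nM.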

Compound 3, half-maximal inhibitory concentration: 11200 nM
For compound 3 the middle estimate is 1.3-fold (0.13 log units) above the measured one, and the stated range covers the measured number.
By their numbers in this assay, from the lowest: compounds 2 and 3 (each within the scatter of the next); then compound 1.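

In this assay, the ring nitrogen of the pyridin-2-yl group proves not to be required at this position: phenyl gives a number that cannot be told apart from that of compound 2 (a 1.4-fold higher number from compound 2 to compound 3 (0.14 log units; within the scatter)). Compound 1 now stands apart from both neighbours, with phenyl also on the favourable side of pyridin-3-yl (a 2.4-fold lower number from compound 1 to compound 3 (0.38 log units; beyond the scatter)). The earlier step therefore reads less as a gain from the pyridin-2-yl nitrogen than as a shortfall tied to pyridin-3-yl in compound 1. Nothing available explains these numbers. On these data alone, whether an aminomethyl group or a carboxylic acid on the phenyl ring would shift the number remains open, as does the effect of a saturated ring such as piperidine at this position.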